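Widening the amide substituent on a shared boron-containing core

A few compounds are considered here, and "the series" means these few. Any claim that something is new, unique, unknown or untested is made for them only; others in the source may bear on it.

Four compounds share one core and differ only in the group attached to the amide nitrogen. Compound 1 `CC(C)(C)NC(=O)CCc1cccc2c1B(O)OC2` carries tert-butyl there; compound 2 `O=C(CCc1cccc2c1B(O)OC2)Nc1ccc(Br)cc1` carries 4-bromophenyl; compound 3 `O=C(CCc1cccc2c1B(O)OC2)Nc1cccc(Br)c1` carries 3-bromophenyl; compound 4 `O=C(CCc1cccc2c1B(O)OC2)Nc1ccc(-c2ccccc2)cc1` is not yet measured. In a functional assay on MDA-MB-231 cells (Homo sapiens) for antiproliferative activity, read by MTT assay, with a stated time of 72 h (on this read-out lower numbers stand for stronger inhibition and higher numbers for weaker inhibition), compound 1 reaches only the limit > 100000 nM, which is a boundary of the measurement rather than a number (the limit of > 100000 nM in this assay, at which 1 of the 3 values shown sits). In this assay compound 2 gives 5300 nM, and compound 3 gives 720 nM. Of the two real numbers, compound 2 stands highest, with compound 3 below it by a 7.4-fold lower number from compound 2 to compound 3 (0.87 log units; beyond the scatter). The step of an at least 18-fold lower number from compound 1 to compound 2 (1.27 log units; beyond the scatter) shows that an aromatic ring on the amide nitrogen matters greatly.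

Compound 4 differs from compound 2 by phenyl in place of bromo on an aromatic carbon. Both steps measured here bear on this change: replacing tert-butyl by an aryl group gave a large step, whereas moving the bromine on that aryl gave a modest one. Exchanging one para substituent for another, larger one is expected to produce a step of a 1.3-fold lower number from compound 2 to compound 4 (0.12 log units; within the scatter), within the scatter. Compound 4 is therefore estimated at 4000 nM in this assay, with a likely range from 800 nM to 20000 nM.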

Compound 4, half-maximal inhibitory concentration: 8800 nM
Compound 4: middle estimate off by 2.2-fold (0.34 log units), on the low side; low and high end bracket the measured number.
By their numbers in this assay, from the lowest: compound 3; then compounds 2 and 4 (each within the scatter of the next). At a limit, above all of these: compound 1.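

The exchange of bromo for phenyl on this aromatic carbon gives a 1.7-fold higher number from compound 2 to compound 4 (0.22 log units; within the scatter) in this assay, so this place on the ring accepts a whole second ring with no change that can be told from the scatter. The earlier steps shown here replaced the entire group on the amide nitrogen or moved the bromine around the ring, whereas this one keeps the place fixed and changes what sits there, going from a single bromine to a six-membered aromatic ring of carbon only while compounds 2 and 4 stay within the scatter of each other. Nothing measured here explains why this exchange leaves the number within the scatter.

The compounds shown leave open whether a group of a different kind at this place, such as an amine or a carboxylic acid, would shift the number beyond the scatter. They also leave open whether phenyl would be accepted as well at the ring place that holds the bromine in compound 3, and whether a longer chain between the shared core and the amide would matter.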